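The compounds below may be only part of what the source reports. "The series", "measured", "known", "first", "only" and "open" are said of these compounds alone.

Working notes on the series: in a functional assay on HL-60 cells (Homo sapiens) for cytotoxicity, read by WST assay, with a stated time of 48 h (on this read-out lower numbers stand for an effect already at smaller amounts and higher numbers for an effect only at larger amounts of compound), compound 1 `O=C1OC[C@H](Cc2ccccc2)[C@H]1Cc1ccccc1` gives 77000 nM and compound 2 `O=C1OC[C@H](Cc2ccccc2)[C@H]1Cc1ccccc1F` gives 72000 nM, which lie within the scatter of each other, as a 1.1-fold lower number from compound 1 to compound 2 (0.03 log units; within the scatter) shows. Compound 3 `O=C1OC[C@H](Cc2ccccc2)[C@H]1Cc1cccc(O)c1` gives only a limit, > 100000 nM. Compound 4 `O=C1OC[C@H](Cc2ccccc2)[C@H]1Cc1ccc(O)cc1` differs from compound 3 as follows: 4-hydroxyphenyl in place of 3-hydroxyphenyl on a saturated chain carbon bound to a saturated ring carbon. The nearest measured steps are an at least 1.2-fold higher number from compound 1 to compound 3 (0.11 log units; that floor lies within the scatter) and an at least 1.3-fold higher number from compound 2 to compound 3 (0.14 log units; that floor lies within the scatter), and both floors lie within the scatter. Among the measured compounds shown here, no measured step moves a hydroxy group around the ring, so no step beyond the scatter is expected in this assay, and no direction is favoured. The expected step is an at least 1.1-fold lower number from compound 3 to compound 4 (0.04 log units; that floor lies within the scatter). The estimate for compound 4 is 90000 nM, with an expected range of 45000 nM to 160000 nM.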

Compound 4, half-maximal effective concentration: 88000 nM
Estimate against measurement, compound 4: 1.0-fold (0.01 log units) above; low and high end bracket the measured number.
By their numbers in this assay, from the lowest: compounds 2, 1 and 4 (each within the scatter of the next). At a limit, above all of these: compound 3.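

Compound 4 carries a hydroxy group and still gives a number rather than a limit in this assay, so this change can be read directly: a 1.1-fold higher number from compound 1 to compound 4 (0.06 log units; within the scatter), and against the fluoro compound a 1.2-fold higher number from compound 2 to compound 4 (0.09 log units; within the scatter). Of the change from 3-hydroxyphenyl to 4-hydroxyphenyl only a floor can be read: an at least 1.1-fold lower number from compound 3 to compound 4 (0.05 log units; that floor lies within the scatter). The value of compound 3 remains a limit of the assay: the limit of > 100000 nM in this assay, at which 1 of the 4 values shown sits.

On these data alone, how far compound 3 really lies from compound 4 stays open. Also open, as far as these compounds go, is whether any group at this place, such as an amine or a carboxylic acid in place of the hydroxy, moves the number beyond the scatter.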